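Aryl amide swaps on a shared core: cytotoxicity notes

A few compounds are considered here, and "the series" means these few. Any claim that something is new, unique, unknown or untested is made for them only; others in the source may bear on it.

Compound 1 `COc1ccc(-c2cnc(NC(=O)c3cccnc3)n2C)cc1`: in a toxicity assay on THP-1 cells (Homo sapiens) for inhibition (on this read-out lower numbers stand for higher toxicity in this test and higher numbers for lower toxicity in this test), compound 1 gives > 100000 nM, a limit of the test.
Compound 2 `COc1ccc(-c2cnc(NC(=O)c3ccc(O)cc3)n2C)cc1`: in this assay compound 2 gives > 100000 nM, again a limit.
Compound 3 `COc1ccc(-c2cnc(NC(=O)c3cnc[nH]3)n2C)cc1`: in this assay compound 3 gives > 100000 nM, also a limit.

Compound 3 therefore stands where all three measured compounds sit, at the limit (the limit of > 100000 nM in this assay, at which 3 of the 3 values shown sit). The steps among them, a step that the two limits leave unreadable from compound 1 to compound 2, a step that the two limits leave unreadable from compound 1 to compound 3 and a step that the two limits leave unreadable from compound 2 to compound 3, carry no readable size. Compound 4 `COc1ccc(-c2cnc(NC(=O)c3ccc(Br)cc3)n2C)cc1` differs from compound 3 by 4-bromophenyl in place of 1H-imidazol-5-yl on a carbonyl carbon. Within the data shown here, no measured step gives a readable size for this kind of change, so no step beyond the scatter can be predicted in this assay, in either direction. Compound 4 is estimated at 100000 nM, within 40000 nM to 300000 nM, most likely again only a limit. That estimate means a step of a number no higher from compound 3 to compound 4 (the limit leaves the size open).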

Compound 4, half-maximal cytotoxic concentration: > 100000 nM
Compound 4: no number, only a limit (the forecaster's own chance of this, stated with the estimate: 75%); the middle value lies on the limit itself.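

The steps from compound 4 to compounds 1, 2 and 3 cannot be read in this assay, since all four values are limits: the limit of > 100000 nM in this assay, at which 4 of the 4 values shown sit.

The compounds shown leave open whether any of these amide swaps changes the read-out at all.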